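The source may report more compounds than this note shows. Statements on the series, on what has been measured and on what is new or still open speak of the compounds shown alone.

Measured compounds in a functional assay on Ehrlich cells (Mus musculus) for cytotoxicity, tested at 100 ug/mL; on this read-out higher numbers stand for a stronger effect at the one concentration tested and lower numbers for a weaker effect:
compound 1, `COc1cc(N2C(N)=C(C#N)C(c3cccs3)C3=C2CC(C)(C)CC3=O)cc(OC)c1OC`, gives 20%
compound 2, `COc1cc(N2C(N)=C(C#N)C(c3ccc(C)cc3)C3=C2CC(C)(C)CC3=O)cc(OC)c1OC`, gives 90%

Compound 2 stands highest of the two numbers; its nearest neighbour is compound 1, which lies well below it. Within the data shown here, the single measured step, a number 70 percentage points higher from compound 1 to compound 2 (beyond the scatter), is the replacement of thiophen-2-yl by 4-methylphenyl on a saturated ring carbon, and it is large and beyond the scatter.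

Compound 3, `COc1cc(N2C(N)=C(C#N)C(/C=C/c3ccccc3)C3=C2CC(C)(C)CC3=O)cc(OC)c1OC`, differs from compound 2 at the same saturated ring carbon: 2-phenylethenyl in place of 4-methylphenyl on a saturated ring carbon. The step from compound 1 to compound 2 is the only one that bears on this change, since it alters the same position, and it shows that a swap of the group there can move this read-out by a large amount in either direction. Among the measured compounds shown here, no measured compound carries 2-phenylethenyl, so the direction for compound 3 is open; the prudent expectation is a value somewhere between the two measured numbers, leaning toward the lower end of the span of compound 2. For compound 3 the value in this assay is estimated at 60%, with a range from 20% to 95%. This estimate means a step of a number 30 percentage points lower from compound 2 to compound 3 (beyond the scatter) is expected.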

Compound 3, a percentage reported as activity, at one concentration (the size of the read-out at that concentration, not a potency): 40%
The estimate for compound 3 lay 20 percentage points above the measured number; the range from low to high includes it.
By their numbers in this assay, from the lowest: compound 1; then compound 3; then compound 2.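

In this assay, the saturated ring carbon now has three groups on record, and they give three separate levels: placing 2-phenylethenyl there instead of 4-methylphenyl gives a number 50 percentage points lower from compound 2 to compound 3 (beyond the scatter) and placing it there instead of thiophen-2-yl gives a number 20 percentage points higher from compound 1 to compound 3 (beyond the scatter) on the same read-out. Compound 3 keeps a six-membered aromatic ring of carbon only, as compound 2 does, yet it does not keep the level of compound 2, so the presence of that ring alone does not fix the read-out at this position. Nothing at hand accounts for the differences among these groups.

Open, going by these compounds, is whether the high level of compound 2 depends on the methyl of 4-methylphenyl, which a plain phenyl at this carbon would test, and whether the lower level of compound 3 depends on the double bond of 2-phenylethenyl, which 2-phenylethyl would test. Also open, on these data alone, is whether the same order of the three groups holds at other concentrations or with other changes to the shared core.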